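The source may report more compounds than this note shows. Statements on the series, on what has been measured and on what is new or still open speak of the compounds shown alone.

- compound 1 `O=C1C(=Cc2ccc(Cl)cc2)C(=O)N(c2ccc(Cl)cc2)N1c1ccc(Cl)cc1`: 17300 nM
- compound 2 `COc1ccccc1C=C1C(=O)N(c2ccc(Cl)cc2)N(c2ccc(Cl)cc2)C1=O`: 30400 nM

In a functional assay on ECa-109 cells (Homo sapiens) for cytotoxicity, read by MTT assay, with a stated time of 72 h (on this read-out higher numbers stand for weaker inhibition and lower numbers for stronger inhibition), compound 2 gives 30400 nM and so sits within the scatter of compound 1. In compound 3 `O=C1C(=C/C=C/c2ccccc2)C(=O)N(c2ccc(Cl)cc2)N1c1ccc(Cl)cc1` the change is 2-phenylethenyl in place of 2-methoxyphenyl on a double-bonded chain carbon bound to a double-bonded ring carbon and it puts 2-phenylethenyl in place of 2-methoxyphenyl on a double-bonded chain carbon bound to a double-bonded ring carbon. For the measured compounds named here, only one measured step touches this place: a 1.8-fold higher number from compound 1 to compound 2 (0.24 log units; within the scatter) stays within the scatter. One step is thin support, but no shift beyond the scatter is expected in this assay in either direction. The expected change is a 1.5-fold lower number from compound 2 to compound 3 (0.18 log units; within the scatter) and it stays within that scatter. Compound 3 is estimated at 20000 nM with a range from 7000 nM to 50000 nM as its expected bounds.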

Compound 3, half-maximal inhibitory concentration: 9900 nM
Compound 3: middle estimate off by 2.0-fold (0.31 log units), on the high side, within the range that was stated.
By their numbers in this assay, from the lowest: compounds 3, 1 and 2 (each within the scatter of the next, the first and the last beyond it).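

In this assay, for the compounds shown here, 2-phenylethenyl in place of 2-methoxyphenyl gives a 3.1-fold lower number from compound 2 to compound 3 (0.49 log units; beyond the scatter) and is the first step at this place to clear the scatter. With 2-phenylethenyl in place of 4-chlorophenyl there is a 1.7-fold lower number from compound 1 to compound 3 (0.24 log units; within the scatter) and no difference can be claimed. Going by these compounds alone, this place therefore responds to the group put on it, though only the pair with the 2-methoxyphenyl group shows this. Nothing given here explains the difference. As far as these compounds go, how an amine or a carboxylic acid on this chain carbon would read in this assay remains open.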